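This account rests on a few compounds, and the source may have more. Where it says the series, first, only, none or still open, it means among the compounds named here.

Series notes, amide-linked thioether set on a shared core.

Compound 1 `O=C(CSc1nc2cccnc2[nH]1)Nc1cccc(Br)c1` is the reference point here. In an assay on isolated protein for inhibition of Ectonucleotide pyrophosphatase/phosphodiesterase family member 1 (Homo sapiens), tested at 10 uM (on this read-out higher numbers stand for more inhibition at the one concentration tested (going by the name of the read-out) and lower numbers for less inhibition), compound 1 gives 23%, the lower of the two numbers recorded so far. Compound 2 `COc1ccc(NC(=O)CSc2nc3ccc(N(C)C)nc3[nH]2)cc1OC` in this assay gives 58%, a number well above that of compound 1 and beyond the scatter; compound 2 differs from compound 1 in more than one place, so the two values are set side by side without a single step being drawn between them.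

Compound 3 `O=C(CSc1nc2cccnc2[nH]1)Nc1ccccc1Cl` is the next entry and has yet to be measured in this assay. Its relation to compound 1 is a single change: 2-chlorophenyl in place of 3-bromophenyl on an amide-type nitrogen. Going by the values given here, no measured pair in this set isolates such a change, so nothing in the numbers points in either direction. The expectation is a step from compound 1 to compound 3 of a number 1 percentage points lower from compound 1 to compound 3 (within the scatter), that is, none beyond the scatter. Compound 3 is accordingly estimated at 22%, with a range from 5% to 42%.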

Compound 3, a percentage reported as inhibition, at one concentration (the size of the read-out at that concentration, not a potency): 19%
The estimate for compound 3 lay 3 percentage points above the measured number; low and high end bracket the measured number.
By their numbers in this assay, from the lowest: compounds 3 and 1 (each within the scatter of the next); then compound 2.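

In this assay, going by these compounds alone, the first single-place step at this amide-type nitrogen is a number 4 percentage points lower from compound 1 to compound 3 (within the scatter), so putting 2-chlorophenyl in place of 3-bromophenyl produces no difference beyond the scatter on the shared core. Halogen identity and the numbered ring position both differ in this one step, so their separate contributions cannot be read, and a lack of net difference does not show that either is without influence. No measured property is available to bear on this result.

On these data alone, what a carboxylic acid or a primary amine on the phenyl ring would do to this read-out remains open. Also open, as far as these compounds go, is whether the same exchange of 2-chlorophenyl for 3-bromophenyl would give a similar result on the core of compound 2.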